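Chromone stilbenes: a trifluoromethoxy variant of compound 3

This account rests on a few compounds, and the source may have more. Where it says the series, first, only, none or still open, it means among the compounds named here.

Three compounds sharing a chromone-like core carrying a styryl arm have been tested in a functional assay on PC-3 cells (Homo sapiens) for antiproliferative activity, read by MTT assay, with a stated time of 12 h; on this read-out lower numbers stand for stronger inhibition and higher numbers for weaker inhibition. In this assay compound 1 `COc1cc(OC)c2c(=O)cc(/C=C/c3ccc(OCC4CC4)cc3)oc2c1` reaches only the limit of the assay, reported as > 40000 nM. Compound 2 `COc1cccc2oc(/C=C/c3ccc(OC(F)(F)F)cc3)cc(=O)c12`, which already carries the trifluoromethoxy group on a differently substituted core, likewise gives only the limit > 40000 nM in this assay. Compound 3 `COc1ccc(/C=C/c2cc(=O)c3c(OC)cc(OC)cc3o2)cc1` stands at the same limit, > 40000 nM, so no real number for it is known. Within the data shown here, the only single-point step among them, a step that the two limits leave unreadable from compound 1 to compound 3, cannot be read because of the limit of > 40000 nM in this assay, at which 3 of the 3 values shown sit, and the same applies to every pair here.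

Compound 4 `COc1cc(OC)c2c(=O)cc(/C=C/c3ccc(OC(F)(F)F)cc3)oc2c1` differs from compound 3 by trifluoromethyl in place of methyl on an oxygen on an aromatic ring. Among the measured compounds shown here, no measured step bears directly on this change, and every value shown sits at the limit. The expectation is therefore that compound 4 will show no change beyond the scatter in this assay, with a step that the limit leaves unreadable from compound 3 to compound 4 estimated from compound 3 to it. Compound 4 is estimated at 50000 nM, within a range from 15000 nM to 200000 nM, most likely again reported only as a limit.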

Compound 4, half-maximal inhibitory concentration: > 40000 nM
Compound 4: only a limit was reported; the forecaster's own chance of this, stated with the estimate: 80%; the middle value does not contradict the limit.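

Compound 4 gives only a limit, so none of its steps from compound 1, compound 2 or compound 3 can be read, because all the compounds share one limit: the limit of > 40000 nM in this assay, at which 4 of the 4 values shown sit.

Whether methoxy to trifluoromethoxy, or any other change among these compounds, alters antiproliferative activity at all stays open, with no real number available for any of them.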